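A few compounds are considered here, and "the series" means these few. Any claim that something is new, unique, unknown or untested is made for them only; others in the source may bear on it.

In a functional assay on ECa-109 cells (Homo sapiens) for cytotoxicity, read by MTT assay, with a stated time of 72 h (on this read-out lower numbers stand for stronger inhibition and higher numbers for weaker inhibition), compound 1 `Cc1cc(Nc2ccc(Cl)cc2)nc(SCc2nc3ccccc3[nH]2)n1` gives 20400 nM and compound 3 `Cc1cc(Nc2ccc(Br)cc2)nc(SCc2nc3ccccc3[nH]2)n1` gives 42900 nM. Compound 2 `Cc1cc(NCCO)nc(SCc2nc3ccccc3[nH]2)n1` gives > 100000 nM, which is a limit of the assay and not a number. Compound 4 `Cc1ccc(Nc2cc(C)nc(SCc3nc4ccccc4[nH]3)n2)cc1` has 4-methylphenyl in place of 2-hydroxyethyl on a nitrogen on an aromatic ring. Two measured steps exchange the same group for a different substituted phenyl: an at least 2.3-fold lower number from compound 2 to compound 3 (0.36 log units; beyond the scatter) and, read in reverse, an at least 4.9-fold higher number from compound 1 to compound 2 (0.69 log units; beyond the scatter). The two halogen compounds themselves differ by a 2.1-fold higher number from compound 1 to compound 3 (0.32 log units; beyond the scatter). A lower number is therefore expected in this assay, and the estimated step is an at least 3.0-fold lower number from compound 2 to compound 4 (0.48 log units; beyond the scatter). For compound 4, the expected value is 33000 nM, within an estimated range of 14000 nM to 80000 nM.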

Compound 4, half-maximal inhibitory concentration: 57300 nM
Estimate against measurement, compound 4: 1.7-fold (0.24 log units) below; the measured number falls inside the stated range.
By their numbers in this assay, from the lowest: compound 1; then compounds 3 and 4 (each within the scatter of the next). At a limit, above all of these: compound 2.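

In this assay, a 4-methylphenyl on this nitrogen shows that the substituted phenyl need not carry a halogen: replacing bromo with methyl gives a 1.3-fold higher number from compound 3 to compound 4 (0.13 log units; within the scatter). Replacing chloro with methyl gives a 2.8-fold higher number from compound 1 to compound 4 (0.45 log units; beyond the scatter), which sets compound 1 apart from both compound 3 and compound 4. The step from the 2-hydroxyethyl compound, an at least 1.7-fold lower number from compound 2 to compound 4 (0.24 log units; that floor lies within the scatter), has only a floor, and the value of compound 2 is a limit of the assay and not a number: the limit of > 100000 nM in this assay, at which 1 of the 4 values shown sits.

The compounds shown leave open how an unsubstituted phenyl, a methoxy on the ring or a benzyl on this nitrogen would read. They also leave open whether the ring or the missing hydroxyl separates compound 4 from compound 2.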